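Iodo Substitution and Liver Microsome Stability of Anilinopyrimidines

A few compounds are considered here, and "the series" means these few. Any claim that something is new, unique, unknown or untested is made for them only; others in the source may bear on it.

The measured compounds:
compound 1, `C=CC(=O)Nc1cc(Nc2ncc(I)c(Nc3ccccc3S(=O)(=O)N(C)C)n2)c(OC)cc1N(C)CCN(C)C`, gives 13%
compound 2, `C=CC(=O)Nc1cc(Nc2nccc(Nc3ccccc3S(=O)(=O)N(C)C)n2)c(OC)cc1N(C)CCN(C)C`, gives 10%
compound 3, `C=CC(=O)Nc1cc(Nc2nccc(Nc3ccccc3S(=O)(=O)C(C)C)n2)c(OC)cc1N(C)CCN(C)C`, gives 5%

These three values come from an ADME assay on microsomes from liver (Homo sapiens) for metabolic stability, read by LC-MS, using NADPH, with a stated time of 30 min, tested at 1 uM; on this read-out lower numbers stand for a less stable compound and higher numbers for a more stable compound. All three compounds sit low on this read-out, and their differences fall within the usual scatter, so no order among them can be claimed. The change from compound 2 to compound 1 is iodo in place of hydrogen on an aromatic carbon and gave a number 3 percentage points higher from compound 2 to compound 1 (within the scatter). The two cores differ as isopropyl in place of dimethylamino on a sulfonyl sulfur, with a number 5 percentage points lower from compound 2 to compound 3 (within the scatter).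

Compound 4, `C=CC(=O)Nc1cc(Nc2ncc(I)c(Nc3ccccc3S(=O)(=O)C(C)C)n2)c(OC)cc1N(C)CCN(C)C`, has not yet been measured. It differs from compound 3 by iodo in place of hydrogen on an aromatic carbon, the same change as from compound 2 to compound 1, made at the same place. The step is expected to be a number 3 percentage points higher from compound 3 to compound 4 (within the scatter), resting on the small step seen in a number 3 percentage points higher from compound 2 to compound 1 (within the scatter) and on compound 3 giving 5%. Compound 4 is therefore estimated to give 8% in this assay, with a range from 3% to 16%.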

Compound 4, percent of the compound remaining: 14%
Beside the measured number, compound 4's estimate is 6 percentage points below it; measured number inside the range.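

In this assay, iodo in place of hydrogen on an aromatic carbon gave a number 9 percentage points higher from compound 3 to compound 4 (within the scatter) and, set beside its first appearance, shows no difference between the two cores: the same change on two cores in this assay, a number 3 percentage points higher (within the scatter) from compound 2 to compound 1 and a number 9 percentage points higher (within the scatter) from compound 3 to compound 4, 6 percentage points apart, within the scatter of two such steps. Isopropyl in place of dimethylamino on a sulfonyl sulfur, now on the iodo-bearing core, gave a number 1 percentage points higher from compound 1 to compound 4 (within the scatter) and likewise shows no difference between cores: the same change on two cores in this assay, a number 5 percentage points lower (within the scatter) from compound 2 to compound 3 and a number 1 percentage points higher (within the scatter) from compound 1 to compound 4, 6 percentage points apart, within the scatter of two such steps. Within these four compounds, each change can therefore be carried from one core to the other without a detectable mismatch, but every step lies within the scatter, so this does not show that either change alters stability or that the two steps would match on any further core.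

The compounds shown leave open whether a chloro, bromo or methyl group on the same aromatic carbon would read like iodo. They also leave open whether a change elsewhere, such as a morpholine in place of the dimethylamino group on the side chain, would move this read-out by more than the scatter.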